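The source may report more compounds than this note shows. Statements on the series, on what has been measured and on what is new or still open speak of the compounds shown alone.

Measured so far in a functional assay on the whole organism with Mus musculus as the target; on this read-out higher numbers stand for an effect only at larger amounts of compound and lower numbers for an effect already at smaller amounts:

- compound 1 `C/C(=C\C(=O)NC1CC1)c1cccc(F)c1`: 46 mg/kg
- compound 2 `NC(=O)/C=C1/CCc2ccccc21`: 44 mg/kg
- compound 3 `NC(=O)/C=C1\CCc2ccc(Cl)cc21`: 40 mg/kg

These three values all lie within the usual scatter of one another, so compound 2 stands level with compound 1 and compound 3 , and none of them can be singled out on these numbers.

The compound still to be measured is compound 4 `NC(=O)/C=C1\CCc2ccccc21`. Its relation to compound 2 is simple: the two compounds have the same atoms and bonds and differ only in configuration as drawn: 1 of 1 stereo elements differ; a double bond is drawn Z in compound 2 and E in compound 4. The double bond is drawn Z in compound 2 and E in compound 4 , and nothing else differs. Among the measured compounds shown here, no measured pair shows a change of this kind, so the data give no direct size for it.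

The expectation therefore starts from compound 2 at 44 mg/kg and from the narrow spread of the measured values. In this assay no step beyond the scatter is expected, in either direction. The estimated change is a 1.1-fold higher number from compound 2 to compound 4 (0.06 log units; within the scatter). For compound 4 the expected value is 50 mg/kg, with an estimated range from 22 mg/kg to 110 mg/kg.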

Compound 4, dose for half-maximal effect: 31 mg/kg
The estimate for compound 4 lay 1.6-fold (0.21 log units) above the measured number; the range from low to high includes it.
By their numbers in this assay, from the lowest: compounds 4, 3, 2 and 1 (each within the scatter of the next).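

The double-bond geometry now has a measured size on this core, and in this assay a 1.4-fold lower number from compound 2 to compound 4 (0.15 log units; within the scatter) stays within the scatter, so the two geometries cannot be told apart on this read-out. This pair isolates that single feature: the fact that compounds 2 and 4 differ only in the configuration as drawn. The second step, with hydrogen in place of chloro on an aromatic carbon, is a 1.3-fold lower number from compound 3 to compound 4 (0.11 log units; within the scatter) and also lies within the scatter, so in this one comparison the chloro group does not set the two compounds apart.

What the compounds shown leave open is whether an amine or a carboxylic acid in place of that chloro would give a step beyond the scatter. They also do not show whether the double-bond geometry would matter any more in a chloro compound, as compound 3 appears here with one geometry only.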